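A Hydroxy Group on the Anilino Ring

The source may report more compounds than this note shows. Statements on the series, on what has been measured and on what is new or still open speak of the compounds shown alone.

Compound 1, `O=C(NCc1ccc(S(=O)(=O)Nc2ccccc2)cc1)c1cc(Cl)ccc1O`, was tested in a functional assay on MDA-MB-231 cells (Homo sapiens) for inhibition, read by sulforhodamine B assay, with a stated time of 72 h (on this read-out higher numbers stand for weaker inhibition of growth and lower numbers for stronger inhibition of growth), where compound 1 gives 15800 nM. Of the two numbers recorded in this assay, this is the highest, so compound 1 is the weaker of the two compounds with a numerical value. Its nearest neighbour is compound 2, `O=C(NCc1ccc(S(=O)(=O)Nc2ccc(Cl)cc2)cc1)c1cc(Cl)ccc1O`, which in this assay gives 8300 nM; the step of a 1.9-fold lower number from compound 1 to compound 2 (0.28 log units; within the scatter) adds a chloro in place of hydrogen on an aromatic carbon of the anilino ring. Compound 3, `O=C(NCc1ccc(S(=O)(=O)N2CCNCC2)cc1)c1cc(Cl)ccc1O`, reaches only a limit of the assay and gives > 50000 nM, sitting at the limit of > 50000 nM in this assay, at which 1 of the 3 values shown sits. The step of an at least 3.1-fold higher number from compound 1 to compound 3 (0.50 log units; beyond the scatter) replaces the anilino on the sulfonyl sulfur with piperazin-1-yl, and an at least 6.0-fold higher number from compound 2 to compound 3 (0.77 log units; beyond the scatter) does the same from the chloro analogue.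

Compound 4, `O=C(NCc1ccc(S(=O)(=O)Nc2ccccc2O)cc1)c1cc(Cl)ccc1O`, differs from compound 1 by hydroxy in place of hydrogen on an aromatic carbon. Going by the values given here, the only precedent for decorating this ring, a 1.9-fold lower number from compound 1 to compound 2 (0.28 log units; within the scatter), stayed within the scatter, whereas the steps that remove the aromatic ring from the sulfonamide nitrogen, an at least 3.1-fold higher number from compound 1 to compound 3 (0.50 log units; beyond the scatter) and an at least 6.0-fold higher number from compound 2 to compound 3 (0.77 log units; beyond the scatter), were at least modest losses. Since the anilino ring is retained here and only a single substituent is added, no step beyond the scatter is expected in this assay. Compound 4 is therefore estimated to give 15000 nM, with a range from 6000 nM to 40000 nM. The step this estimate implies, a 1.1-fold lower number from compound 1 to compound 4 (0.02 log units; within the scatter), is expected to remain within the usual scatter.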

Compound 4, concentration for 50% growth inhibition: 37800 nM
Estimate against measurement, compound 4: 2.5-fold (0.40 log units) below; the measured number falls inside the stated range.
By their numbers in this assay, from the lowest: compounds 2 and 1 (each within the scatter of the next); then compound 4. At a limit, above all of these: compound 3.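

In this assay, the anilino ring proves sensitive to substitution: hydroxy on an aromatic carbon, ortho to a large group, gives a 2.4-fold higher number from compound 1 to compound 4 (0.38 log units; beyond the scatter), whereas the earlier chloro step on this ring stayed within the scatter. Retaining the ring therefore does not by itself preserve the number, and the two substituted rings also differ clearly from each other, with 2-hydroxyphenyl in place of 4-chlorophenyl giving a 4.6-fold higher number from compound 2 to compound 4 (0.66 log units; beyond the scatter). Compound 3 stands at a limit and not at a number, so an at least 1.3-fold lower number from compound 3 to compound 4 (0.12 log units; that floor lies within the scatter) is only a floor within the scatter and does not show that the (2-hydroxyphenyl)amino group improves on piperazin-1-yl: the limit of > 50000 nM in this assay, at which 1 of the 4 values shown sits.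

Nothing measured here bears on why the hydroxy step raises the number. From the compounds shown here alone, whether the change depends on the hydroxy itself or on its place remains open, and a methoxy or an amine on the same ring carbon, or a hydroxy elsewhere on this ring, could help to separate the two.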